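A few compounds are considered here, and "the series" means these few. Any claim that something is new, unique, unknown or untested is made for them only; others in the source may bear on it.

Measured so far:
Compound 1 `CCCCCCCCc1cn([C@H]2C[C@@H]3OP(=O)(O)OC[C@H]3O2)c(=O)[nH]c1=O` gives 184 ug/mL in a functional assay on Raji cells (Homo sapiens); a lower number here means a stronger inhibitor, a higher number a weaker inhibitor.
Compound 2 `CCCCc1cn([C@H]2C[C@H](O)[C@@H](CO)O2)c(=O)[nH]c1=O` reaches only > 500 ug/mL in this assay, which is a limit of the assay and not a number.

Going by the values given here, compound 1 holds the only number; the other entry sits at the limit of > 500 ug/mL in this assay, at which 1 of the 2 values shown sits. Compound 3 `CCCc1cn([C@H]2C[C@@H]3OP(=O)(O)OC[C@H]3O2)c(=O)[nH]c1=O` remains to be measured. It differs from compound 1 by hydrogen in place of pentyl on a saturated chain carbon, three bonds along the chain from an aromatic carbon. Among the compounds with values here, no measured pair covers this change on its own, so the step is expected rather than known: a loss of potency beyond the scatter, a 2.2-fold higher number from compound 1 to compound 3 (0.34 log units; beyond the scatter), is expected. Compound 3 is therefore estimated at 400 ug/mL, between 150 ug/mL and 900 ug/mL, with a real chance that only a limit is returned.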

Compound 3, concentration for 50% inhibition: > 500 ug/mL
Compound 3 ended at the assay's limit; the forecaster's own chance of this, stated with the estimate: 45%; at least 1.2-fold (0.09 log units) between middle value and limit.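

In this assay, replacing pentyl with hydrogen at this saturated chain carbon, which turns octyl into propyl on the shared core, gives an at least 2.7-fold higher number from compound 1 to compound 3 (0.43 log units; beyond the scatter). Going by these compounds alone, this is the first single-place reading, and it shows that the octyl chain of compound 1 carries measurable potency compared with propyl. Compound 3 gives a limit of the assay and not a number, so the full size of the step stays unresolved: the limit of > 500 ug/mL in this assay, at which 2 of the 3 values shown sit.

Chains of intermediate length remain open, as does the shape of the trend between propyl and octyl. Also open, on these data alone, is whether a decyl chain or a chain ending in an amine would give a lower number than compound 1.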